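Notes on three measured compounds and one new analogue

The compounds below may be only part of what the source reports. "The series", "measured", "known", "first", "only" and "open" are said of these compounds alone.

Measured so far:
Compound 1 `COc1ccc(OC)c(/C=N/NC(=O)Nc2ccc(Oc3ccnc(-c4nncn4CCN(C)C)c3)c(F)c2)c1` gives 2070 nM
Compound 2 `COc1ccc(/C=N/NC(=O)Nc2ccc(Oc3ccnc(-c4nncn4CCN(C)C)c3)c(F)c2)c(OC)c1OC` gives 3970 nM
Compound 3 `CN(C)CCn1cnnc1-c1cc(Oc2ccc(NC(=O)N/N=C/c3c(O)ccc4ccccc34)cc2F)ccn1` gives 670 nM

In a functional assay on HT-29 cells (Homo sapiens) for cytotoxicity, read by MTT assay, with a stated time of 72 h (on this read-out lower numbers stand for stronger inhibition and higher numbers for weaker inhibition), compound 1 stands second highest of the three numbers. Its nearest neighbour is compound 2, a 1.9-fold higher number from compound 1 to compound 2 (0.28 log units; within the scatter); its furthest is compound 3, a 3.1-fold lower number from compound 1 to compound 3 (0.49 log units; beyond the scatter).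

Compound 4 `COc1cc(/C=N/NC(=O)Nc2ccc(Oc3ccnc(-c4nncn4CCN(C)C)c3)c(F)c2)ccc1O` is not yet measured. It differs from compound 1 by 4-hydroxy-3-methoxyphenyl in place of 2,5-dimethoxyphenyl on a carbon with a double bond to nitrogen. One hydrogen-bond donor enters with the 4-hydroxy-3-methoxyphenyl group. Going by the values given here, the step that bears on this is the one to compound 3, which also brought in a hydroxy-bearing aryl group and was modest, a 3.1-fold lower number from compound 1 to compound 3 (0.49 log units; beyond the scatter); a 5.9-fold lower number from compound 2 to compound 3 (0.77 log units; beyond the scatter) points the same way. Exchange between methoxy-bearing aryl groups alone, a 1.9-fold higher number from compound 1 to compound 2 (0.28 log units; within the scatter), stayed within the scatter. A modest lower number is therefore expected, a 1.5-fold lower number from compound 1 to compound 4 (0.17 log units; within the scatter). Compound 4 is expected at 1400 nM, with a range from 600 nM to 3300 nM.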

Compound 4, half-maximal inhibitory concentration: 120 nM
Compound 4: middle estimate off by 12-fold (1.07 log units), on the high side; measured number below the stated range.
By their numbers in this assay, from the lowest: compound 4; then compound 3; then compounds 1 and 2 (each within the scatter of the next).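

On the carbon with a double bond to nitrogen, 4-hydroxy-3-methoxyphenyl gives a 17-fold lower number from compound 1 to compound 4 (1.24 log units; beyond the scatter) and a 33-fold lower number from compound 2 to compound 4 (1.52 log units; beyond the scatter) in this assay, so the aryl group at this position can move the number far more than the exchange among methoxy-bearing groups indicated. A hydroxy group alone does not fix the number: 2-hydroxynaphthalen-1-yl also carries one, and the change to 4-hydroxy-3-methoxyphenyl still gives a 5.6-fold lower number from compound 3 to compound 4 (0.75 log units; beyond the scatter). No evidence on the reason for these steps is at hand.

The compounds shown do not separate the contribution of the hydroxy group from that of its place on the ring. A 3,4-dimethoxyphenyl or 4-amino-3-methoxyphenyl group at this position would bear on that question.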